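The compounds below may be only part of what the source reports. "The series", "measured", "known", "first", "only" and "open" are said of these compounds alone.

Working notes on the series in an in vitro ADME assay on microsomes (Rattus norvegicus) for metabolic stability; on this read-out higher numbers stand for fast clearance and lower numbers for slow clearance. Of the compounds shown here, three have numbers so far: compound 1 `O=C(CN(C(=O)c1ccc(-n2ccnc2)cc1)C1CCCCC1)Nc1cc(F)cc(F)c1` gives 1.2 mL.min-1.g-1, compound 2 `O=C(CN(C(=O)c1ccc(-c2ccccn2)cc1)C1CCCCC1)Nc1cc(F)cc(F)c1` gives 15.4 mL.min-1.g-1 and compound 3 `O=C(CN(CC1CC1)C(=O)c1ccc(-c2ccccn2)cc1)Nc1cc(F)cc(F)c1` gives 5 mL.min-1.g-1. That puts compound 3 in the middle of the three numbers, with gaps beyond the scatter on both sides.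

The unmeasured compound 4 `O=C(CN(C(=O)c1ccc(-c2ccccn2)cc1)C1CCCOC1)Nc1cc(F)cc(F)c1` has oxan-3-yl in place of cyclopropylmethyl on an amide-type nitrogen. The most relevant measured change at this nitrogen is the modest step of a 3.1-fold lower number from compound 2 to compound 3 (0.49 log units; beyond the scatter), with cyclopropylmethyl in place of cyclohexyl. The large step of a 13-fold higher number from compound 1 to compound 2 (1.11 log units; beyond the scatter) lies at another place, pyridin-2-yl in place of 1H-imidazol-1-yl on an aromatic carbon, and gives no direct guide here.

Among the compounds with values here, no measured compound carries a ring with a hetero atom on this nitrogen, so the direction rests on thin evidence. Compound 2, at 15.4 mL.min-1.g-1, suggests that a ring taking the place of cyclopropylmethyl could raise the number, but only slightly. The expected change in this assay is small and within the scatter, an estimated 1.4-fold higher number from compound 3 to compound 4 (0.15 log units; within the scatter). For compound 4 the estimated value is 7 mL.min-1.g-1, with an expected range from 2.5 mL.min-1.g-1 to 18 mL.min-1.g-1.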

Compound 4, intrinsic clearance in microsomes: 2 mL.min-1.g-1
The estimate for compound 4 lay 3.5-fold (0.54 log units) above the measured number; the whole stated range lies above it.
By their numbers in this assay, from the lowest: compounds 1 and 4 (each within the scatter of the next); then compound 3; then compound 2.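

Oxan-3-yl on the amide-type nitrogen gives a 2.5-fold lower number from compound 3 to compound 4 (0.40 log units; beyond the scatter) when it replaces cyclopropylmethyl, and a 7.7-fold lower number from compound 2 to compound 4 (0.89 log units; beyond the scatter) when it replaces cyclohexyl, in this assay. Within the data shown here, the earlier compounds showed only one change at this nitrogen, from one carbon-only group to another, in which the ring of cyclopropylmethyl gave the lower number; compound 4 now shows that a group with more heavy atoms than cyclopropylmethyl, and with a hetero atom in its ring, can stand lowest of the three compounds that share the pyridin-2-yl group. Among these three, the number therefore does not simply follow the heavy-atom count of the incoming group, and nothing at hand accounts for the shift.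

The compounds shown leave open whether the place of the ring oxygen matters, as oxan-4-yl would test, and whether a ring amine such as piperidin-4-yl at this nitrogen would behave like oxan-3-yl. They also leave open whether oxan-3-yl lowers the number to a similar degree when 1H-imidazol-1-yl replaces pyridin-2-yl on the aromatic carbon.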